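The source may hold more compounds than are shown below. What is called first, only, known or untested is meant among the compounds shown, and "the series" means these compounds.

Measured compounds in a functional assay on DU-145 cells (Homo sapiens) for inhibition, read by trypan blue exclusion, with a stated time of 72 h; a lower number here means a stronger inhibitor, a higher number a weaker inhibitor:
- compound 1, `Cn1c(=O)c(S(=O)(=O)c2ccc(F)cc2F)cc2cnc(Nc3cccc4[nH]ccc34)nc21`: 750 nM
- compound 2, `Cn1ccc2cc(Nc3ncc4cc(S(=O)(=O)c5ccc(F)cc5F)c(=O)n(C)c4n3)ccc21`: 750 nM
- compound 3, `Cn1c(=O)c(S(=O)(=O)c2ccc(F)cc2F)cc2cnc(Nc3ccc4c(c3)C(=O)C(=O)N4)nc21`: 75000 nM

Compound 1 stands level with compound 2 in this assay, the two together at the lowest number of the three, the step of no change at the digits printed from compound 1 to compound 2 (within the scatter) lying within the scatter. Among the compounds with values here, compound 3 sits far from both, with a 100-fold higher number from compound 1 to compound 3 (2.00 log units; beyond the scatter) and a 100-fold higher number from compound 2 to compound 3 (2.00 log units; beyond the scatter) as the only large steps in the set.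

Compound 4, `COc1ccc(S(=O)(=O)c2cc3cnc(Nc4cccc5[nH]ccc45)nc3n(C)c2=O)cc1`, differs from compound 1 at a different place: 4-methoxyphenyl in place of 2,4-difluorophenyl on a sulfonyl sulfur. Every measured step here alters the group on the nitrogen on the aromatic ring of the shared core, while the (2,4-difluorophenyl)sulfonyl arm is kept unchanged in compound 1, compound 2 and compound 3. Within the data shown here, no measured pair therefore bears directly on the exchange of the aryl on the sulfonyl sulfur, and the size of its effect in this assay cannot be read from the data. With nothing pointing either way, a step of at most modest size, in either direction, is expected; the estimated step of a 1.3-fold higher number from compound 1 to compound 4 (0.12 log units; within the scatter) is centred on no change beyond the scatter. Compound 4 is thus expected to give 1000 nM in this assay, within a range of 250 nM to 4000 nM.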

Compound 4, half-maximal inhibitory concentration: 5000 nM
Compound 4: middle estimate off by 5.0-fold (0.70 log units), on the low side; the measured number lies above the stated range.
By their numbers in this assay, from the lowest: compounds 1 and 2 (each within the scatter of the next); then compound 4; then compound 3.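

The aryl on the sulfonyl sulfur is not a silent part of these structures in this assay: 4-methoxyphenyl in place of 2,4-difluorophenyl gives a 6.7-fold higher number from compound 1 to compound 4 (0.82 log units; beyond the scatter), a modest step beyond the scatter. Within the data shown here, until now, every measured step had altered the group on the nitrogen on the aromatic ring, and this pair is the first to show that the number also moves with the group on the sulfonyl sulfur, with the 2,4-difluorophenyl of compound 1 giving the lower number of the two. Among these compounds, no experimental information is available to explain this step, and the single pair cannot separate the two fluorine atoms that leave from the methoxy group that enters.

The compounds shown leave open whether the loss of the fluorine atoms or the arrival of the methoxy group carries the step, and how a plain phenyl, or a phenyl bearing a chlorine, an amine or a carboxylic acid, would stand on the same sulfur. They also leave open whether the same exchange gives a step of similar size when the 1-methyl-1H-indol-5-yl group of compound 2 sits on the shared core.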